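The source may hold more compounds than are shown below. What is called first, only, known or untested is meant among the compounds shown, and "the series" means these compounds.

From the compounds shown here alone, compound 3 `CC(C)c1cc(C(=O)N2CCc3c(sc(NCc4ccc(F)cc4)c3C#N)C2)[nH]n1` gives "not determined" (no result reported) in a functional assay on Chem-3 cells for antagonist activity at metabotropic glutamate receptor 1 (Homo sapiens), read by fluorescence and calcium flux; a lower number here means a stronger inhibitor, a higher number a weaker inhibitor; no number was reported for it, so where it stands is unknown. Compound 4 `N#Cc1c(NCc2ccc(F)cc2)sc2c1CCN(C(=O)c1ccn[nH]1)C2` is obtained from it by a single change: hydrogen in place of isopropyl on an aromatic carbon. This same change has been measured once in this series. Compound 1 `CC(C)c1cc(C(=O)N2CCc3c(sc(NCc4ccccc4)c3C#N)C2)[nH]n1` gives 43200 nM in this assay. Compound 2 `N#Cc1c(NCc2ccccc2)sc2c1CCN(C(=O)c1ccn[nH]1)C2` carries hydrogen where compound 1 carries isopropyl; in this assay compound 2 gives 1090 nM. That step, a 40-fold lower number from compound 1 to compound 2 (1.60 log units; beyond the scatter), is large and clearly beyond the scatter. Compound 4 stands to compound 3 exactly as compound 2 stands to compound 1, so a step of similar size toward a lower number is expected in this assay, although without a value for compound 3 the step cannot be anchored there. The estimate for compound 4 rests instead on compound 2, which already carries this hydrogen and gives 1090 nM. Compound 4 is expected to give 1100 nM in this assay, with a range from 300 nM to 4000 nM.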

Compound 4, half-maximal inhibitory concentration: 2030 nM
Beside the measured number, compound 4's estimate is 1.8-fold (0.27 log units) below it; the measured number falls inside the stated range.
By their numbers in this assay, from the lowest: compounds 2 and 4 (each within the scatter of the next); then compound 1.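

Fluoro in place of hydrogen on an aromatic carbon gives a 1.9-fold higher number from compound 2 to compound 4 (0.27 log units; within the scatter) in this assay and this step lies within the scatter. With hydrogen in place of isopropyl on the 1H-pyrazol-5-yl group, this fluoro therefore leaves the number indistinguishable from that of compound 2, so the result with hydrogen at this position now holds for two compounds rather than one. Nothing at hand explains these numbers.

From the compounds shown here alone, the step from compound 3 to compound 4 cannot be read, so it remains unknown whether removing isopropyl has as large an effect when the fluoro is present. Going by these compounds, it also remains open how a methyl group, an amine or a carboxylic acid at this same place on the ring would compare with hydrogen and isopropyl.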